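The source may hold more compounds than are shown below. What is called first, only, known or untested is meant among the compounds shown, and "the series" means these compounds.

Measured compounds:
- compound 1, `COc1ccc(S(=O)(=O)N2CCc3cccc(NC(=O)c4ccc([N+](=O)[O-])cc4)c32)cc1`: 102 nM
- compound 2, `COc1ccc(S(=O)(=O)N2CCc3cccc(NS(=O)(=O)c4ccc([N+](=O)[O-])cc4)c32)cc1`: 1100 nM
- compound 3, `COc1ccc(C(=O)Nc2cccc3c2N(S(=O)(=O)c2ccc(OC)cc2)CC3)cc1`: 2600 nM

All three were tested in a functional assay on KB cells (Homo sapiens) for cytotoxicity; a lower number here means a stronger inhibitor, a higher number a weaker inhibitor. Compound 3 gives the highest number of the three, so it is the weakest inhibitor of the set; compound 2 stands nearest to it and compound 1 furthest. Compound 4, `COc1ccc(S(=O)(=O)N2CCc3cccc(NS(=O)(=O)c4ccc(F)cc4)c32)cc1`, has not yet been measured. It differs from compound 3 in one place: (4-fluorophenyl)sulfonyl in place of (4-methoxyphenyl)carbonyl on a nitrogen on an aromatic ring.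

For the measured compounds named here, no measured step covers this exact change. Going by the values given here, the only measured step, a 25-fold higher number from compound 1 to compound 3 (1.41 log units; beyond the scatter), concerns the ring substituent, where methoxy in place of nitro raised the number sharply. Compound 1 and compound 2 show what carbonyl against sulfonyl does with nitro in place: compound 1 gives 102 nM while compound 2 gives 1100 nM, a higher number for the sulfonyl. Compound 4 carries the sulfonyl with fluorine instead of methoxy, and nothing measured here tells how fluorine compares with methoxy. Weighing the higher number seen for the sulfonyl against the uncertain effect of fluorine, compound 4 is expected to stay weak, around 3000 nM, with a likely range from 800 nM to 12000 nM; the step of a 1.2-fold higher number from compound 3 to compound 4 (0.06 log units; within the scatter) is an estimate only.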

Compound 4, half-maximal inhibitory concentration: 1200 nM
Compound 4: the middle estimate sits 2.5-fold (0.40 log units) above what was measured; the range from low to high includes it.
By their numbers in this assay, from the lowest: compound 1; then compounds 2 and 4 (each within the scatter of the next); then compound 3.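

In this assay, (4-fluorophenyl)sulfonyl in place of (4-methoxyphenyl)carbonyl on this nitrogen gives a 2.2-fold lower number from compound 3 to compound 4 (0.34 log units; beyond the scatter), so a sulfonyl here need not go with the weakest number, even though compound 1 at 102 nM and compound 2 at 1100 nM pointed that way. Among the sulfonyl compounds, fluoro in place of nitro on an aromatic carbon gives a 1.1-fold higher number from compound 2 to compound 4 (0.04 log units; within the scatter), so these two cannot be told apart, whereas among the carbonyl compounds methoxy in place of nitro gives a 25-fold higher number from compound 1 to compound 3 (1.41 log units; beyond the scatter). No measurement shown here explains either result.

The step from compound 3 to compound 4 swaps both the link and the ring group, and the compounds shown do not separate the share of each. Also open, as far as these compounds go, is how an amine or a carboxylic acid would read in place of fluoro on that aromatic carbon.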